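A few compounds are considered here, and "the series" means these few. Any claim that something is new, unique, unknown or untested is made for them only; others in the source may bear on it.

Measured in an ADME assay on RAW264.7 cells (Mus musculus) for cytotoxicity, read by MTT assay; on this read-out lower numbers stand for stronger inhibition and higher numbers for weaker inhibition:
- compound 1 `CCCCCCCCCCOc1cccc(O)c1C(=O)/C=C/c1ccc(O)cc1`: > 30000 nM (a limit)
- compound 2 `CCCCCCCCCCCCOc1cccc(O)c1C(=O)/C=C/c1ccc(O)cc1`: > 30000 nM (a limit)

Compound 2 has no numerical value, only the limit > 30000 nM. Within the data shown here, the series so far offers only (the limit of > 30000 nM in this assay, at which 2 of the 2 values shown sit). Compound 3 `CCCCC/C=C\CCCCOc1cccc(O)c1C(=O)/C=C/c1ccc(O)cc1` differs from it by hept-1-en-1-yl in place of octyl on a saturated chain carbon, four bonds along the chain from an oxygen on an aromatic ring. Among the measured compounds shown here, the one measured step that bears on this, also a change in the chain, is a step that the two limits leave unreadable from compound 1 to compound 2. With no readable size to carry over, no step beyond the usual scatter is expected in this assay, in either direction. The expected change is a number no higher from compound 2 to compound 3 (the limit leaves the size open). For compound 3 the estimate is 30000 nM, with an expected range of 12000 nM to 60000 nM.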

Compound 3, half-maximal inhibitory concentration: > 30000 nM
Compound 3: a limit, no number; the forecaster's own chance of this, stated with the estimate: 80%; the middle value sits exactly at the limit.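

In this assay compound 3 gives > 30000 nM, a limit and not a number. Among these compounds, no step among compound 1, compound 2 and compound 3 can be read. How these chains compare remains open, because none of the three compounds gives a number: the limit of > 30000 nM in this assay, at which 3 of the 3 values shown sit.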